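Removing the benzyl trifluoromethyl group: outlook for compound 4

The source may report more compounds than this note shows. Statements on the series, on what has been measured and on what is new or still open speak of the compounds shown alone.

Compound 1 `O=S(=O)(NCCCNCc1ccccc1Cl)c1cc(C(F)(F)F)cc(C(F)(F)F)c1` gives 15000 nM in a functional assay on PANC-1 cells (Homo sapiens) for inhibition, read by MTT assay, with a stated time of 72 h; a lower number here means a stronger inhibitor of growth, a higher number a weaker inhibitor of growth. Compound 2 `O=S(=O)(NCCCCNCc1ccc(Br)cc1)c1cc(C(F)(F)F)cc(C(F)(F)F)c1` gives 2200 nM, and compound 3 `O=S(=O)(NCCCNCc1ccc(C(F)(F)F)cc1)c1cc(C(F)(F)F)cc(C(F)(F)F)c1` gives 3200 nM. Compound 3 thus stands second highest of the three numbers; its value lies within the scatter of compound 2, while the step of a 4.7-fold lower number from compound 1 to compound 3 (0.67 log units; beyond the scatter) is beyond the scatter. Compound 4 `O=S(=O)(NCCCNCc1ccccc1)c1cc(C(F)(F)F)cc(C(F)(F)F)c1` differs from compound 3 by hydrogen in place of trifluoromethyl on an aromatic carbon. Within the data shown here, no measured step removes a benzyl substituent outright; the steps of a 6.8-fold lower number from compound 1 to compound 2 (0.83 log units; beyond the scatter) and a 4.7-fold lower number from compound 1 to compound 3 (0.67 log units; beyond the scatter) only exchange one substituted benzyl for another and were modest. The change is therefore expected to cost little in this assay, at most a small rise that may stay within the scatter. Compound 4 is estimated at 6000 nM, range 2000 nM to 20000 nM. The expected step is a 1.9-fold higher number from compound 3 to compound 4 (0.27 log units; within the scatter).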

Compound 4, concentration for 50% growth inhibition: 16000 nM
The estimate for compound 4 lay 2.7-fold (0.43 log units) below the measured number, within the range that was stated.
By their numbers in this assay, from the lowest: compounds 2 and 3 (each within the scatter of the next); then compounds 1 and 4 (each within the scatter of the next).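

In this assay the step of a 5.0-fold higher number from compound 3 to compound 4 (0.70 log units; beyond the scatter) shows that hydrogen in place of trifluoromethyl at this position is not neutral, a loss the earlier exchanges of one substituted benzyl for another could not show. Hydrogen in place of chloro is different: a 1.1-fold higher number from compound 1 to compound 4 (0.03 log units; within the scatter) stays within the scatter, while a 7.3-fold higher number from compound 2 to compound 4 (0.86 log units; beyond the scatter) again lies beyond it. No evidence on why these steps differ is available.

On these data alone, whether trifluoromethyl is special at this position remains open, since a nitrile or methoxy group there would test that. The contributions of the longer chain and the bromo group in compound 2 also remain unseparated.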